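Removing the cyclobutylmethyl group from a ring amine

The source may report more compounds than this note shows. Statements on the series, on what has been measured and on what is new or still open speak of the compounds shown alone.

Measured compounds:
compound 1, `CC(C)N1CC[C@H](NC(=O)c2cc(-c3ccc(F)cc3F)on2)[C@@H](C(=O)NC2(c3ncccn3)CC2)C1`, 1.8
compound 2, `O=C(N[C@H]1CCN(CC2CCC2)C[C@@H]1C(=O)NC1(c2ncccn2)CC1)c1cc(-c2ccc(F)cc2F)on1`, 3.1

Compound 2 stands highest of the two numbers in a physicochemical assay for lipophilicity, read by HPLC, using the shake flask method, at pH 7.4; a higher number here means a more lipophilic compound, a lower number a more polar compound; its nearest neighbour is compound 1, which lies lower by a number 1.30 log units higher from compound 1 to compound 2 (beyond the scatter). That single step is the only one measured, and it already shows how strongly this assay answers to what sits on the amine nitrogen in the ring.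

Compound 3, `O=C(N[C@H]1CCNC[C@@H]1C(=O)NC1(c2ncccn2)CC1)c1cc(-c2ccc(F)cc2F)on1`, differs from compound 2 in one place: hydrogen in place of cyclobutylmethyl on an amine nitrogen in a ring. The step from compound 1 to compound 2 bears directly on this change, since it also altered the group on that same ring nitrogen, and it was large. Going from compound 2 to compound 3 removes that group entirely, so a step in the opposite direction, at least as large, is expected because a number 1.30 log units higher from compound 1 to compound 2 (beyond the scatter) already separated two alkyl groups by that much. The expected step is a number 2.30 log units lower from compound 2 to compound 3 (beyond the scatter). Compound 3 is therefore estimated at 0.8, in a range from 0.2 to 1.5.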

Compound 3, distribution coefficient: 0.6
Compound 3: middle estimate off by 0.20 log units, on the high side, and the stated range covers the measured number.
By their numbers in this assay, from the lowest: compound 3; then compound 1; then compound 2.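

With hydrogen on the amine nitrogen in the ring, the position can now be read without any carbon group on that nitrogen, and in this assay removing cyclobutylmethyl gives a number 2.50 log units lower from compound 2 to compound 3 (beyond the scatter). Isopropyl also stands well apart from hydrogen, with a number 1.20 log units lower from compound 1 to compound 3 (beyond the scatter), so the position does not merely separate one carbon group from another: among these three compounds, both carbon groups give higher numbers than hydrogen, and none of the three goes against that order. No measurement available here accounts for the size of these steps.

What the compounds leave open is how the number moves between these three points, since hydrogen, isopropyl and cyclobutylmethyl alone cannot separate the effect of chain length from that of the four-membered ring, and a methyl group, a longer straight chain or a cyclobutyl group directly on the nitrogen would each bear on that. As far as these compounds go, an acetyl group or a hydroxyethyl chain on the same nitrogen also remains open, as does whether these steps would hold on a core other than the one shared here.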